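This account rests on a few compounds, and the source may have more. Where it says the series, first, only, none or still open, it means among the compounds named here.

The series shares the core of compound 1 `CCN(CC)S(=O)(=O)c1ccc(S(=O)(=O)N2CCC[C@@H](C(=O)N[C@H]3CC[C@H](OC)CC3)C2)cc1`, with only the amide substituent varied. In a functional assay on MIA PaCa-2 cells (Homo sapiens) for inhibition, read by MTT assay, with a stated time of 3 days (on this read-out lower numbers stand for stronger inhibition and higher numbers for weaker inhibition), compound 1 gives only a limit of the assay, > 10000 nM. Compound 2 `CCN(CC)S(=O)(=O)c1ccc(S(=O)(=O)N2CCC[C@@H](C(=O)N3CCC(O)CC3)C2)cc1` likewise gives only a limit in this assay, > 10000 nM. Compound 3 `CCN(CC)S(=O)(=O)c1ccc(S(=O)(=O)N2CCC[C@@H](C(=O)N3CCC(F)(F)CC3)C2)cc1` also gives only a limit in this assay, > 10000 nM. Compound 3 thus stands at the limit with the rest of the set, as recorded in the limit of > 10000 nM in this assay, at which 3 of the 3 values shown sit; the steps a step that the two limits leave unreadable from compound 1 to compound 3 and a step that the two limits leave unreadable from compound 2 to compound 3 cannot be sized from two limits. Compound 4 `CCN(CC)S(=O)(=O)c1ccc(S(=O)(=O)N2CCC[C@@H](C(=O)N3CCC(C(F)F)CC3)C2)cc1` differs from compound 3 by 4-(difluoromethyl)piperidin-1-yl in place of 4,4-difluoropiperidin-1-yl on a carbonyl carbon. Within the data shown here, no measured step reads on this change, so no shift beyond the scatter is expected; the estimated step is a step that the limit leaves unreadable from compound 3 to compound 4. Compound 4 is expected at 15000 nM, within 5000 nM to 50000 nM, most probably reported again only as a limit.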

Compound 4, half-maximal inhibitory concentration: > 10000 nM
Compound 4: a limit, no number; the forecaster's own chance of this, stated with the estimate: 85%; the middle value lies beyond the limit too.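

No step to compound 4 from compound 1, compound 2 or compound 3 can be read, as compound 4 also gives only a limit: the limit of > 10000 nM in this assay, at which 4 of the 4 values shown sit.

The compounds shown leave open whether any amide substituent on the shared core gives a measurable value in this assay.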